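A few compounds are considered here, and "the series" means these few. Any claim that something is new, unique, unknown or untested is made for them only; others in the source may bear on it.

Compound 1 `COc1ccc2ncc(S(=O)(=O)c3ccc(C)c(Cl)c3)c(N3CCC(C)CC3)c2c1` and compound 2 `Cc1ccc(S(=O)(=O)c2cnc3cc(F)ccc3c2N2CCC(C)CC2)cc1Cl` carry the same sulfonyl-linked aryl group on cores that are not identical; the difference between the two cores is not broken down here. Compound 3 `COc1ccc2ncc(S(=O)(=O)c3cccc(C#N)c3)c(N3CCC(C)CC3)c2c1` is compound 1 with the change (3-cyanophenyl in place of 3-chloro-4-methylphenyl on a sulfonyl sulfur). In an assay on isolated protein for displacement of a labelled ligand from metabotropic glutamate receptor 5 (Homo sapiens), with a stated time of 60 min, tested at 1 uM (a higher number here means more inhibition at the concentration tested (going by the name of the read-out), a lower number less inhibition), compound 1 gives 85%, compound 2 gives 93%, and compound 3 gives 90%. The step of a number 5 percentage points higher from compound 1 to compound 3 (within the scatter) is therefore small. Compound 4 `CC1CCN(c2c(S(=O)(=O)c3cccc(C#N)c3)cnc3cc(F)ccc23)CC1` is compound 2 with the same change, (3-cyanophenyl in place of 3-chloro-4-methylphenyl on a sulfonyl sulfur). Because the measured step of a number 5 percentage points higher from compound 1 to compound 3 (within the scatter) stayed within the scatter, the step of no change at the digits printed from compound 2 to compound 4 (within the scatter) is expected to be of similar size, limited by the fact that the number for compound 2 is already high. For compound 4 in this assay an inhibition of about 93% is expected, most likely between 82% and 99%.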

Compound 4, a percentage reported as inhibition, at one concentration (the size of the read-out at that concentration, not a potency): 92%
Estimate against measurement, compound 4: 1 percentage points above; the measured number falls inside the stated range.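

In this assay, putting 3-cyanophenyl in place of 3-chloro-4-methylphenyl on the sulfonyl sulfur gives a number 1 percentage points lower from compound 2 to compound 4 (within the scatter). Set beside the earlier case, the change behaves alike on the two cores: the same change on two cores in this assay, a number 5 percentage points higher (within the scatter) from compound 1 to compound 3 and a number 1 percentage points lower (within the scatter) from compound 2 to compound 4, 6 percentage points apart, within the scatter of two such steps. This shows that the swap moved the number beyond the scatter on neither core, but it does not give a difference in potency, since each number comes from one concentration, and two cores are too few to make a rule for the whole series.

On these data alone, it remains open how this assay would respond to an aryl group carrying an amine or a carboxylic acid in place of the nitrile.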